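From Isopropyl to Ethyl on the Amine Nitrogen

A few compounds are considered here, and "the series" means these few. Any claim that something is new, unique, unknown or untested is made for them only; others in the source may bear on it.

In a physicochemical assay for lipophilicity, read by HPLC, using the shake flask method (on this read-out lower numbers stand for lower lipophilicity and higher numbers for higher lipophilicity), compound 1 `C/C(=N\C#N)N(Cc1ccc(Cl)nc1)C(C)C` gives 1.46. Compound 3 `CC(C)/C(=N\C#N)N(C)Cc1ccc(Cl)nc1` gives 1.39, a value that cannot be told apart from that of compound 1. Compound 2 `CC/C(=N\C#N)N(C)Cc1ccc(Cl)nc1` gives 1.12, and its gap to compound 1 lies beyond the scatter.

Compound 4 `CCN(Cc1ccc(Cl)nc1)/C(C)=N/C#N` has not yet been measured. Its difference from compound 1 is hydrogen in place of methyl on a saturated chain carbon bound to an amine nitrogen and a saturated chain carbon, with hydrogen in place of methyl on a saturated chain carbon bound to an amine nitrogen and a saturated chain carbon, so that isopropyl becomes ethyl.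

Going by the values given here, only one measured step offers a guide, and it sits elsewhere in the structure: a number 0.27 log units higher from compound 2 to compound 3 (within the scatter), with methyl in place of hydrogen on a saturated chain carbon bound to a carbon with a double bond to nitrogen and a saturated chain carbon. Read in reverse, this step suggests a lower number of similar size, which may not clear the scatter. The expected change is a number 0.27 log units lower from compound 1 to compound 4 (within the scatter). Compound 4 is estimated at 1.19, with an expected range from 0.93 to 1.45.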

Compound 4, partition coefficient: 1.19
The estimate for compound 4 equals the measured number at the digits printed, and the stated range covers the measured number.
By their numbers in this assay, from the lowest: compounds 2, 4, 3 and 1 (each within the scatter of the next, the first and the last beyond it).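

The change from isopropyl to ethyl on the amine nitrogen gives in this assay a number 0.27 log units lower from compound 1 to compound 4 (within the scatter), so this single change does not separate the two groups on this read-out. Going by these compounds alone, it is the first step read at this place, on a saturated chain carbon bound to an amine nitrogen and a saturated chain carbon, whereas the earlier step, a number 0.27 log units higher from compound 2 to compound 3 (within the scatter), lay elsewhere in the structure. Nothing at hand accounts for the size of the new step.

Going by these compounds, whether a longer chain such as butyl, or a cyclopropyl group, on the amine nitrogen would give a number beyond the scatter from compound 1 remains open. So does whether the change from isopropyl to ethyl would give a step of the same size on a different core.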